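Swapping 2-methoxyphenyl for 4-methoxyphenyl

The compounds below may be only part of what the source reports. "The series", "measured", "known", "first", "only" and "open" are said of these compounds alone.

In a functional assay on IMR-32 cells (Homo sapiens) for inhibition, with a stated time of 48 h, tested at 50 uM (on this read-out higher numbers stand for more inhibition of growth at the one concentration tested and lower numbers for less inhibition of growth), compound 1 `C=C[C@@](C)(/C=C/c1ccc(OC(=O)CCC)cc1)CCC=C(C)C` gives 54% and compound 2 `CC[C@](C)(CCCC(C)C)CCc1ccc(O)cc1` gives 53% and these two lie within the scatter of each other. Compound 3 `COc1ccccc1/C=C/[C@@](C)(/C=C/c1ccc(O)cc1)CCC=C(C)C` reaches 68% as the highest of the three numbers, and its gap to each of the other two lies beyond the scatter. Compound 4 `COc1ccc(/C=C/[C@@](C)(/C=C/c2ccc(O)cc2)CCC=C(C)C)cc1` has not yet been measured. It carries 4-methoxyphenyl in place of 2-methoxyphenyl on a double-bonded chain carbon bound to a double-bonded chain carbon so the two have the same atoms, joined differently. Among the compounds with values here, no two measured compounds differ in one place, so the numbers give no direct guide to this change. Compound 3 at 68% is therefore the only anchor for the expectation. In this assay the estimated result is a number 3 percentage points lower from compound 3 to compound 4 (within the scatter) and no step beyond the scatter is expected. For compound 4 the estimated value is 65% with an expected range from 52% to 78% in this measurement.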

Compound 4, percent growth inhibition at one concentration: 6%
Beside the measured number, compound 4's estimate is 59 percentage points above it, and the stated range ends above it.
By their numbers in this assay, from the lowest: compound 4; then compounds 2 and 1 (each within the scatter of the next); then compound 3.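

Within the data shown here, replacing 2-methoxyphenyl with 4-methoxyphenyl on a double-bonded chain carbon bound to a double-bonded chain carbon gives, in this assay, a number 62 percentage points lower from compound 3 to compound 4 (beyond the scatter) and is the first single-place comparison in this set. The two groups match in every count given, including heavy atoms, ring, donors and acceptors, so these counts do not separate them, and growth inhibition at this place depends strongly on how the same atoms are joined. The data offer no measurement that explains this difference.

The compounds shown leave open whether a plain phenyl or a hydroxyphenyl at this place would give a number nearer that of compound 3 or that of compound 4. Going by these compounds, whether this step would hold at other concentrations also remains open, since only one concentration is reported.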